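Working notes: hydroxy to sulfooxy

The compounds below may be only part of what the source reports. "The series", "measured", "known", "first", "only" and "open" are said of these compounds alone.

Going by the values given here, in an ADME assay on the whole organism (plasma, strain F344/DuCrlCrlj) for pharmacokinetics, with Rattus norvegicus as the target, read by LC-MS, at a dose of 1 mg/kg by the oral route (a higher number here means more compound in the circulation at the dose given, a lower number less compound in the circulation), compound 2 (`Cn1c(COc2ccc(CC3SC(=O)NC3=O)cc2)nc2ccc(O)cc21`) gives 280 ng.h/mL, the higher of the two numbers so far, and compound 1 (`COc1ccc2nc(COc3ccc(CC(C(N)=O)S(C)(=O)=O)cc3)n(C)c2c1`) gives 9.85 ng.h/mL, a gap beyond the scatter. Compound 3 (`Cn1c(COc2ccc(CC3SC(=O)NC3=O)cc2)nc2ccc(OS(=O)(=O)O)cc21`) carries sulfo in place of hydrogen on an oxygen on an aromatic ring. Among the compounds with values here, no measured pair shows this change, so its size remains poorly constrained. The expected step, a 1.4-fold higher number from compound 2 to compound 3 (0.15 log units; within the scatter), is a slight rise that stays within the scatter, with wide uncertainty. For compound 3 the estimated value is 400 ng.h/mL, with an expected range of 80 ng.h/mL to 2000 ng.h/mL.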

Compound 3, area under the concentration-time curve: 11000 ng.h/mL
For compound 3 the middle estimate is 28-fold (1.44 log units) below the measured one; measured number outside the range, above it.
By their numbers in this assay, from the lowest: compound 1; then compound 2; then compound 3.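

Hydroxy to sulfooxy is the first change in one place that can be read in this assay, and it gives a 39-fold higher number from compound 2 to compound 3 (1.59 log units; beyond the scatter). One substitution on this oxygen on an aromatic ring is therefore enough to move the number well beyond the scatter. Nothing available bears on the reason for this rise.

Going by these compounds, whether another group on this oxygen, such as a phosphate or an acetyl, gives a step of similar size remains open. So does whether hydroxy to sulfooxy behaves the same way on a different core.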